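From a Diethylamino Chain End to a Cyano Group

The compounds below may be only part of what the source reports. "The series", "measured", "known", "first", "only" and "open" are said of these compounds alone.

Measured in a functional assay on HepG2 cells (Homo sapiens) for antiproliferative activity, read by MTT assay, with a stated time of 48 h; on this read-out lower numbers stand for stronger inhibition and higher numbers for weaker inhibition:
- Compound 1 `CCn1c(C(=O)NCCCN(C)C)ccc1C(CC)(CC)c1ccc(OCCC(O)(CC)CC)c(C)c1`: 110 nM
- Compound 2 `CCn1c(C(=O)NCCN(C)C)ccc1C(CC)(CC)c1ccc(OCCC(O)(CC)CC)c(C)c1`: 240 nM
- Compound 3 `CCN(CC)CCNC(=O)c1ccc(C(CC)(CC)c2ccc(OCCC(O)(CC)CC)c(C)c2)n1CC`: 230 nM

Compound 3 cannot be told apart from compound 2, and both carry higher numbers than compound 1. Compound 4 `CCn1c(C(=O)NCC#N)ccc1C(CC)(CC)c1ccc(OCCC(O)(CC)CC)c(C)c1` has not been measured. It differs from compound 3 by cyano in place of (diethylamino)methyl on a saturated chain carbon bound to an amide-type nitrogen.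

Among the measured compounds shown here, three measured steps bear on this change: a 2.2-fold higher number from compound 1 to compound 2 (0.34 log units; beyond the scatter), a 2.1-fold higher number from compound 1 to compound 3 (0.32 log units; beyond the scatter) and a 1.0-fold lower number from compound 2 to compound 3 (0.02 log units; within the scatter). All of them exchange one amino-bearing chain end for another, and none removes the amino group, so they offer only loose guidance. Since those steps are small, a modest step towards a higher number is expected in this assay, although the direction remains uncertain. The expected change is a 1.7-fold higher number from compound 3 to compound 4 (0.24 log units; within the scatter). For compound 4 the estimated value is 400 nM, with an expected range of 120 nM to 1300 nM.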

Compound 4, half-maximal inhibitory concentration: > 50000 nM
Compound 4 ended at the assay's limit; the forecaster's own chance of this, stated with the estimate: 5%; middle value at least 120-fold (2.09 log units) from the limit.
By their numbers in this assay, from the lowest: compound 1; then compounds 3 and 2 (each within the scatter of the next). At a limit, above all of these: compound 4.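

The earlier steps shown here only exchanged one amino-bearing chain end for another and stayed small, whereas putting cyano at this place gives an at least 210-fold higher number from compound 3 to compound 4 (2.33 log units; beyond the scatter), an at least 200-fold higher number from compound 2 to compound 4 (2.31 log units; beyond the scatter) and an at least 450-fold higher number from compound 1 to compound 4 (2.65 log units; beyond the scatter). On this saturated chain carbon bound to an amide-type nitrogen, the numbers in this assay therefore stay close across the amino-bearing chain ends but not with cyano, an exchange that removes the amino group and also shrinks the group at this place from 6 heavy atoms to 2. The result for compound 4 is a limit and not a number: the limit of > 50000 nM in this assay, at which 1 of the 4 values shown sits.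

The compounds shown do not separate the loss of the amino group from the shortening of the chain end. On these data alone, it remains open whether a longer chain ending in cyano, or a short chain ending in a primary amine, would stay near compound 1, compound 2 and compound 3.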